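Swapping the benzyl substituent in a cytotoxic series

The compounds below may be only part of what the source reports. "The series", "measured", "known", "first", "only" and "open" are said of these compounds alone.

Measured compounds:
Compound 1, `C=C(Br)C(=O)Nc1cccc(/C=C2\SC(=O)N(Cc3ccc(C)cc3)C2=O)c1`, 1000 nM
Compound 2, `C=C(Br)C(=O)Nc1cccc(/C=C2\SC(=O)N(Cc3ccccc3)C2=O)c1`, 810 nM
Compound 3, `C=C(Br)C(=O)Nc1cccc(/C=C2\SC(=O)N(Cc3ccc(C(C)(C)C)cc3)C2=O)c1`, 5200 nM

These three compounds were tested in a functional assay on FM3A cells (Mus musculus) for cytotoxicity, read by cell counting, with a stated time of 2 days; a higher number here means a weaker inhibitor, a lower number a stronger inhibitor. Compound 3 gives the highest number of the three; its nearest neighbour is compound 1, and the step of a 5.2-fold higher number from compound 1 to compound 3 (0.72 log units; beyond the scatter) lies beyond the scatter, as does a 6.4-fold higher number from compound 2 to compound 3 (0.81 log units; beyond the scatter). Compound 1 and compound 2 sit within the scatter of each other, shown by a 1.2-fold lower number from compound 1 to compound 2 (0.09 log units; within the scatter).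

Compound 4, `C=C(Br)C(=O)Nc1cccc(/C=C2\SC(=O)N(Cc3cccc(F)c3)C2=O)c1`, is not yet measured. The change from compound 3 is 3-fluorophenyl in place of 4-(tert-butyl)phenyl on a saturated chain carbon bound to an amide-type nitrogen in a ring. The two steps that bear on it are a 6.4-fold higher number from compound 2 to compound 3 (0.81 log units; beyond the scatter) and a 5.2-fold higher number from compound 1 to compound 3 (0.72 log units; beyond the scatter), both modest and both moving the number up when the larger group enters. Going the other way, toward a group closer in size to that of compound 2, a modest move to a lower number in this assay is therefore expected, and compound 4 is estimated at 900 nM, within 400 nM to 2500 nM. The expected step is a 5.8-fold lower number from compound 3 to compound 4 (0.76 log units; beyond the scatter).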

Compound 4, half-maximal inhibitory concentration: 690 nM
Estimate against measurement, compound 4: 1.3-fold (0.12 log units) above; low and high end bracket the measured number.
By their numbers in this assay, from the lowest: compounds 4, 2 and 1 (each within the scatter of the next); then compound 3.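

In this assay, a fluorine-bearing ring at this position behaves differently from the other substituted ring: 3-fluorophenyl shows a 1.2-fold lower number from compound 2 to compound 4 (0.07 log units; within the scatter) and a 1.4-fold lower number from compound 1 to compound 4 (0.16 log units; within the scatter), both within the scatter, so this change leaves the number where the unsubstituted and 4-methylphenyl compounds already stood. The replacement of 4-(tert-butyl)phenyl by 3-fluorophenyl gives a 7.5-fold lower number from compound 3 to compound 4 (0.88 log units; beyond the scatter), so among the four compounds only the 4-(tert-butyl)phenyl compound stands apart, and a substituent placed differently on the ring now joins the hydrogen and methyl cases. Nothing available explains why these compounds group this way.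

From the compounds shown here alone, it remains open whether a phenyl ring carrying a methoxy group, an amine or a carboxylic acid would stay with compounds 4, 2 and 1 or move toward compound 3. A longer chain between the ring and the amide-type nitrogen is also untested in what is shown here.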